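Swapping the ethynyl for a hydroxymethyl on an amide carbonyl

The source may report more compounds than this note shows. Statements on the series, on what has been measured and on what is new or still open speak of the compounds shown alone.

Three compounds sharing an amide core were tested in a functional assay on HCT-116 cells (Homo sapiens) for inhibition, read by MTT assay, with a stated time of 48 h; on this read-out higher numbers stand for weaker inhibition and lower numbers for stronger inhibition. Compound 1 `C/C=C/C(=O)N(Cc1cc(OC)c(OC)c(OC)c1)c1ccc(OC)c(O)c1` gives 8450 nM, compound 2 `C#CC(=O)N(Cc1ccc(OC)c(O)c1)c1cc(OC)c(OC)c(OC)c1` gives 310 nM, and compound 3 `C/C=C/C(=O)N(Cc1ccc(OC)c(Cl)c1)c1cc(OC)c(OC)c(OC)c1` gives 1420 nM. Compound 2 has the lowest number of the three; the next closest is compound 3, with a number higher by a margin beyond the usual scatter, and compound 1 is furthest away, well beyond the scatter.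

Compound 4 `COc1ccc(CN(C(=O)CO)c2cc(OC)c(OC)c(OC)c2)cc1O` is not yet measured. It differs from compound 2 in one place: hydroxymethyl in place of ethynyl on a carbonyl carbon. Nothing measured here shows a single change of this kind, so the expectation rests on compound 2 alone and on the fact that compound 1 and compound 3, which carry other groups on the carbonyl carbon, both give higher numbers.

The step is expected to go towards weaker inhibition, and by a margin beyond the scatter, so that in this assay compound 4 is estimated at 5000 nM, within a range from 1500 nM to 20000 nM, an expected shift of a 16-fold higher number from compound 2 to compound 4 (1.21 log units; beyond the scatter).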

Compound 4, half-maximal inhibitory concentration: 520 nM
Estimate against measurement, compound 4: 9.6-fold (0.98 log units) above, and the stated range ends above it.
By their numbers in this assay, from the lowest: compounds 2 and 4 (each within the scatter of the next); then compound 3; then compound 1.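

In this assay, for the compounds shown here, the one step that can be read is a 1.7-fold higher number from compound 2 to compound 4 (0.22 log units; within the scatter), so ethynyl and hydroxymethyl on this carbonyl carbon cannot be told apart here. For this pair, then, a triple bond at this position is not required for a number of this size, and a group with a hydrogen-bond donor and acceptor, which ethynyl lacks, does just as well. No measurement shown explains why the two groups give such close numbers.

From the compounds shown here alone, whether this position would accept an aminomethyl, a carboxylic acid or a longer chain such as hydroxyethyl remains open. Going by these compounds, compound 1 and compound 3 differ from compound 2 in more than one place, so their steps cannot be read, and the contribution of this position to their higher numbers stays unknown.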